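The source may report more compounds than this note shows. Statements on the series, on what has been measured and on what is new or still open speak of the compounds shown alone.

Working notes on the series.

Compound 1 `CC1=C(C(=O)OC(C)(C)C)C(c2ccoc2)NC(=O)N1` is the reference point. In an assay on membranes from HeLa cells for displacement of a labelled ligand from adenosine receptor A3 (Homo sapiens), read by scintillation counting, with a stated time of 180 min, tested at 1 uM (a higher number here means more inhibition at the concentration tested (going by the name of the read-out), a lower number less inhibition), compound 1 gives 2%, the lowest of the three numbers recorded so far. Compound 2 `CC1=C(C(=O)OC(C)(C)C)C(c2cccs2)NC(=O)N1` gives 7% in this assay, and compound 3 `CC1=C(C(=O)OC(C)(C)C)C(c2ccoc2)NC(=O)N1C` gives 12%. Both measured steps, a number 5 percentage points higher from compound 1 to compound 2 (within the scatter) and a number 10 percentage points higher from compound 1 to compound 3 (within the scatter), stay within the usual scatter, so none of the three compounds can be ordered against the others on these numbers; all three sit at a low level of inhibition.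

Compound 4 `CC1=C(C(=O)OC2CCCCC2)C(c2ccoc2)NC(=O)N1` is not yet measured. Its difference from compound 1 is cyclohexyl in place of tert-butyl on an oxygen next to a carbonyl group. Neither measured step touches the ester oxygen: one step changes the aryl group on the saturated ring carbon, the other adds a methyl on the amide-type nitrogen in the ring, and both came out flat. For the measured compounds named here, there is therefore no measured step that bears directly on the change in compound 4, and the series so far offers no movement beyond the scatter at all.

The expectation for compound 4 is accordingly a step of a number 4 percentage points higher from compound 1 to compound 4 (within the scatter), that is, no change beyond the scatter. Compound 4 is estimated at 6% in this assay, with a range from 0% to 20%.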

Compound 4, a percentage reported as inhibition, at one concentration (the size of the read-out at that concentration, not a potency): 1%
Beside the measured number, compound 4's estimate is 5 percentage points above it; low and high end bracket the measured number.
By their numbers in this assay, from the lowest: compounds 4, 1, 2 and 3 (each within the scatter of the next, the first and the last beyond it).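

The ester oxygen now has a measured step of its own: in this assay cyclohexyl in place of tert-butyl on an oxygen next to a carbonyl group gives a number 1 percentage points lower from compound 1 to compound 4 (within the scatter), so a third place on the shared core shows a single change that stays within the scatter. Replacing the open tert-butyl with a ring of carbon only therefore leaves compound 4 at 1% in the same low range of inhibition as the other compounds, and the series still holds no step beyond the scatter from compound 1. No measurement at hand offers an explanation for this flat step.

Whether any group on this oxygen can move the number remains open, as the compounds shown cover only tert-butyl and cyclohexyl, and say nothing of a benzyl group, a short ethyl chain, or a carboxylic acid in place of the ester. Also open, on these data alone, is whether cyclohexyl on this oxygen combined with methyl on the amide-type nitrogen, or with thiophen-2-yl on the saturated ring carbon, would stay equally flat.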